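The source may report more compounds than this note shows. Statements on the series, on what has been measured and on what is new or still open speak of the compounds shown alone.

Compound 1 `CCCCCCCCCCCCNC(=O)[C@@H](N)CCCCN` gives 794 nM in a functional assay on HL-60 cells (Homo sapiens) for activation; a lower number here means that less compound is needed, a higher number that more compound is needed for the effect; its enantiomer compound 2 `CCCCCCCCCCCCNC(=O)[C@H](N)CCCCN` gives 794 nM, so the step of no change at the digits printed from compound 1 to compound 2 (within the scatter) is flat, in keeping with the fact that compounds 1 and 2 differ only in the configuration as drawn. These two share the highest number of the three measured; compound 3 `CCCCCCCCCCCCCCCCNCC(N)CCCCN`, which differs in chain length and in the linking group, gives 251 nM, a lower number.

Compound 4 `CCCCCCCCCCCCCCNC(=O)[C@@H](N)CCCCN` carries ethyl in place of hydrogen on a saturated chain carbon, ten or more bonds along the chain from an amide-type nitrogen. Among the measured compounds shown here, no measured single step covers such an extension; the only measured step, from compound 1 to compound 2, concerns configuration and is flat, so it gives no guide to direction or size. Compound 3 shows that a longer chain can go together with a lower number, but not in isolation. For compound 4 a modest move toward a lower number is expected, a 1.6-fold lower number from compound 1 to compound 4 (0.20 log units; within the scatter), with an estimate of 500 nM (range 200 nM to 1250 nM).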

Compound 4, half-maximal effective concentration: 501 nM
For compound 4 the middle estimate is 1.0-fold (0.00 log units) below the measured one, and the stated range covers the measured number.
By their numbers in this assay, from the lowest: compounds 3, 4, 1 and 2 (each within the scatter of the next, the first and the last beyond it).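

In this assay, ethyl in place of hydrogen on a saturated chain carbon, ten or more bonds along the chain from an amide-type nitrogen, gives a 1.6-fold lower number from compound 1 to compound 4 (0.20 log units; within the scatter). Among the compounds shown here, this is the first single step on chain length, and with the amide kept, the extension leaves the number within the scatter. Nothing at hand gives a reason for this step.

As far as these compounds go, whether a longer chain, such as butyl or hexyl in place of hydrogen at this place, would move the number beyond the scatter stays open. Also open, from the compounds shown here alone, is what the amide carbonyl contributes on its own, since compound 3 combines a longer chain with a plain amine link.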